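The compounds below may be only part of what the source reports. "The series", "measured", "known", "first", "only" and "open" are said of these compounds alone.

Working notes, series around the shared core of compound 1 `O=C(O)COC/C=C1\C[C@H]2C[C@@H](O)[C@H](/C=N/NC(=O)Nc3ccc(Cl)c(Cl)c3)[C@H]2C1`. In a functional assay on a cell-free system (plasma) for agonist activity at thromboxane A2 receptor (Homo sapiens) (a lower number here means a stronger inhibitor, a higher number a weaker inhibitor), compound 1 gives 180 nM, the highest of the three numbers; compound 2 `O=C(O)CCC/C=C1/C[C@H]2C[C@@H](O)[C@H](/C=N/NC(=O)Nc3ccccc3)[C@H]2C1`, with 100 nM, lies within the scatter of it, whereas compound 3 `O=C(O)COC/C=C1/C[C@H]2C[C@@H](O)[C@H](/C=N/NC(=O)Nc3ccc(Cl)c(Cl)c3)[C@H]2C1`, with 60 nM, lies beyond it, the step of a 3.0-fold lower number from compound 1 to compound 3 (0.48 log units; beyond the scatter) resting only on (the fact that compounds 1 and 3 differ only in the configuration as drawn).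

Compound 4 `O=C(O)COC/C=C1\C[C@H]2C[C@@H](O)[C@H](/C=N/NC(=O)Nc3cccc(Cl)c3)[C@H]2C1` is to be measured in this assay. It differs from compound 1 by hydrogen in place of chloro on an aromatic carbon. Going by the values given here, no measured step touches the aryl group, so the change is uncalibrated; compound 2, with an unsubstituted phenyl but a different chain and geometry, only shows a number close to that of compound 1. A step within the scatter is therefore expected, a 1.1-fold higher number from compound 1 to compound 4 (0.05 log units; within the scatter), and compound 4 is estimated at 200 nM, between 70 nM and 600 nM.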

Compound 4, half-maximal inhibitory concentration: 1600 nM
Compound 4: middle estimate off by 8.0-fold (0.90 log units), on the low side; the measured number lies above the stated range.
By their numbers in this assay, from the lowest: compounds 3, 2 and 1 (each within the scatter of the next, the first and the last beyond it); then compound 4.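

Going from 3,4-dichlorophenyl to 3-chlorophenyl gives an 8.9-fold higher number from compound 1 to compound 4 (0.95 log units; beyond the scatter), the first measured step on the aryl group. The chloro para to a large group therefore counts in this assay, and the remaining chloro on the ring does not make up for its loss. Nothing available accounts for the size of this step.

Still open, as far as these compounds go, is whether a fluoro or methyl group at this position would keep the number of compound 1. Also open, from the compounds shown here alone, is whether a 4-chlorophenyl group would do so, and whether the same loss appears with the double bond drawn as in compound 3.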